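The source may report more compounds than this note shows. Statements on the series, on what has been measured and on what is new or still open speak of the compounds shown alone.

Measured so far in a functional assay, with a stated time of 60 min, tested at 0.1 mM; on this read-out lower numbers stand for a weaker effect and higher numbers for a stronger effect at the one concentration tested:
compound 1, `Cn1c(=O)c(C(=O)NCCN)c(O)c2ccccc21`: 11.5%
compound 2, `NCCNC(=O)c1c(O)c2ccccc2n(-c2ccccc2)c1=O`: 10%
compound 3, `Cn1c(=O)c(C(=O)NCCCCCCNC(=O)CCCCC2CCSS2)c(O)c2ccccc21`: 13%

From compound 1 to compound 2 the change is phenyl in place of methyl on an aromatic nitrogen; the step is a number 1.5 percentage points lower from compound 1 to compound 2 (within the scatter). Compound 3 carries a different side chain on the shared core; how its core differs from that of compound 1 is not broken down here. The read-outs of compound 3 and compound 1, and of compound 3 and compound 2, lie within the scatter of one another, so no ordering is drawn among the three.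

Compound 4, `O=C(CCCCC1CCSS1)NCCCCCCNC(=O)c1c(O)c2ccccc2n(-c2ccccc2)c1=O`, is not yet measured. It differs from compound 3 by phenyl in place of methyl on an aromatic nitrogen. This is the same kind of change as from compound 1 to compound 2, the surroundings differing only in that the position is meta to a large group in compound 3, against meta to a (2-aminoethyl)carbamoyl group (6 heavy atoms) in compound 1. Going by the values given here, the step from compound 3 to compound 4 is expected to be a number 1.5 percentage points lower from compound 3 to compound 4 (within the scatter), resting on the one measured instance, a number 1.5 percentage points lower from compound 1 to compound 2 (within the scatter). For compound 4 the estimate is 11.5%, expected between 4% and 20%.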

Compound 4, a percentage reported as activity, at one concentration (the size of the read-out at that concentration, not a potency): 10.2%
For compound 4 the middle estimate is 1.3 percentage points above the measured one; the range from low to high includes it.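

In this assay, going by these compounds alone, phenyl in place of methyl on an aromatic nitrogen gives a number 2.8 percentage points lower from compound 3 to compound 4 (within the scatter), so on the core of compound 3 this change leaves no step that can be told from the scatter. Set beside the earlier step, the change carries from one side chain to the other with no difference that can be read: the same change on two cores in this assay, a number 1.5 percentage points lower (within the scatter) from compound 1 to compound 2 and a number 2.8 percentage points lower (within the scatter) from compound 3 to compound 4, 1.3 percentage points apart, within the scatter of two such steps. Within the data shown here, this shows only that the two steps agree within the scatter at the one concentration tested; it gives no potency, and it does not show that the same would hold on any further core or at any other concentration.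

Still open, on these data alone, is whether a group other than methyl or phenyl on that aromatic nitrogen, such as ethyl or benzyl, would give a step beyond the scatter. Also open, as far as these compounds go, is how a longer chain in the side chain of compound 3, or a carboxylic acid in place of the amine of compound 1, would read in this assay.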